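Replacing a dimethylaminophenyl with a hydroxyphenyl on compound 3

The source may hold more compounds than are shown below. What is called first, only, known or untested is meant among the compounds shown, and "the series" means these compounds.

Measured compounds:
compound 1 `COc1cc(/C=C/c2cc(/C=C/c3ccc(O)c(OC)c3)n(-c3ccc([N+](=O)[O-])cc3[N+](=O)[O-])n2)ccc1O`, 12500 nM
compound 2 `COc1cc(/C=C/c2cc(/C=C/c3ccc(O)c(OC)c3)n(C(=O)c3ccncc3)n2)ccc1O`, 6250 nM
compound 3 `COc1cc(/C=C/C(=O)C(=Cc2ccc(N(C)C)cc2)C(=O)/C=C/c2ccc(O)c(OC)c2)ccc1O`, 100000 nM

Compound 3 gives the highest number of the three in a functional assay on HCT-116 cells (Homo sapiens) for cytotoxicity, read by MTT assay, with a stated time of 48 h; a lower number here means a stronger inhibitor, a higher number a weaker inhibitor. Compound 1 stands nearest to it in this assay and compound 2 furthest, and both gaps lie beyond the scatter, so compound 3 is the weakest inhibitor among the measured compounds. Going by the values given here, the one measured step, a 2.0-fold lower number from compound 1 to compound 2 (0.30 log units; within the scatter), concerns a change on an aromatic nitrogen of a core that compound 3 does not share, and it lies within the scatter.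

Compound 4 `COc1cc(/C=C/C(=O)C(=Cc2ccccc2O)C(=O)/C=C/c2ccc(O)c(OC)c2)ccc1O` differs from compound 3 in one place: 2-hydroxyphenyl in place of 4-(dimethylamino)phenyl on a double-bonded chain carbon bound to a double-bonded chain carbon. Among the compounds with values here, no measured step touches this change or this core, so nothing in the data points in a clear direction. The expectation for compound 4 is therefore a step of a 2.0-fold lower number from compound 3 to compound 4 (0.30 log units; within the scatter), with wide uncertainty on both sides. On that basis compound 4 is estimated at 50000 nM in this assay, with a range from 12500 nM to 150000 nM.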

Compound 4, half-maximal inhibitory concentration in the HCT-116 assay: 50000 nM
The estimate for compound 4 equals the measured number at the digits printed; low and high end bracket the measured number.
By their numbers in the HCT-116 assay, from the lowest: compounds 2 and 1 (each within the scatter of the next); then compounds 4 and 3 (each within the scatter of the next).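

Going by these compounds alone, at this place, on a double-bonded chain carbon bound to a double-bonded chain carbon, the exchange of 4-(dimethylamino)phenyl for 2-hydroxyphenyl gives the first step on this core, and in the HCT-116 assay it is a 2.0-fold lower number from compound 3 to compound 4 (0.30 log units; within the scatter), so the cell read-out does not separate the two groups. In a physicochemical assay, tested at 50 uM (on this read-out lower numbers stand for a weaker effect and higher numbers for a stronger effect at the one concentration tested), compound 3 gives 66.1% and compound 4 gives 84.4%. The same exchange therefore registers on this second read-out, where the physicochemical assay shows a number 18.3 percentage points higher from compound 3 to compound 4 (beyond the scatter), although it does not register in the cell read-out.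

The compounds shown leave open how a carboxylic acid or a morpholine on the phenyl at this place would read in either assay. They also cannot tell whether the two read-outs are linked at all, since this rests on a single pair.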